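The source may report more compounds than this note shows. Statements on the series, on what has been measured and on what is new or still open speak of the compounds shown alone.

In a functional assay on MCF7 cells (Homo sapiens) for inhibition, read by MTT assay, with a stated time of 3 days (a higher number here means a weaker inhibitor, a lower number a stronger inhibitor), two compounds on the shared core have been measured so far. Compound 1 (`COc1cc(-c2nc3ccccc3s2)ccc1OCC(=O)NNC(=O)CN(C(C)=O)[C@@H](CS)C(=O)O`) gives 1750 nM in this series, and compound 2 (`COc1cc(-c2nc3ccccc3s2)ccc1OCC(=O)NNC(=O)CN1CCC[C@H]1C(=O)O`) gives 840 nM and holds the lower of the two numbers, making it the stronger inhibitor of the pair.

Compound 3 (`CCOC(=O)CN(C)CC(=O)NNC(=O)COc1ccc(-c2nc3ccccc3s2)cc1OC`) keeps the core and changes one group on a saturated chain carbon bound to a carbonyl carbon (((ethoxycarbonyl)methyl)(methyl)amino in place of 2-carboxypyrrolidin-1-yl on a saturated chain carbon bound to a carbonyl carbon). The five-membered non-aromatic ring leaves, and the entering group has no ring and no defined stereocentre.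

Among the compounds with values here, one measured step bears on this place (a 2.1-fold lower number from compound 1 to compound 2 (0.32 log units; beyond the scatter)) and it is modest. Within the data shown here, it is the only guide, and no measured compound carries the entering group, so the data give no firm direction. The expected change is a 1.1-fold lower number from compound 2 to compound 3 (0.02 log units; within the scatter) in this assay and so no step beyond the scatter, though a modest move either way would not be surprising. For compound 3 the estimate is 800 nM in this assay with an expected range of 250 nM to 2500 nM for now.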

Compound 3, half-maximal inhibitory concentration: 1980 nM
For compound 3 the middle estimate is 2.5-fold (0.39 log units) below the measured one; the measured number falls inside the stated range.
By their numbers in this assay, from the lowest: compound 2; then compounds 1 and 3 (each within the scatter of the next).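

In this assay, replacing 2-carboxypyrrolidin-1-yl with ((ethoxycarbonyl)methyl)(methyl)amino on this saturated chain carbon gives a 2.4-fold higher number from compound 2 to compound 3 (0.37 log units; beyond the scatter), so this place responds to a change between two groups of equal heavy-atom count, though the step is modest. The second comparison gives a 1.1-fold higher number from compound 1 to compound 3 (0.05 log units; within the scatter), which places the ethyl ester of compound 3 level with the acetyl(1-carboxy-2-sulfanylethyl)amino group of compound 1; among these three compounds, the presence of a free carboxylic acid therefore does not track the number, and only compound 2, with the five-membered non-aromatic ring, stands apart as the strongest inhibitor. No supporting data accompany these results to explain the differences.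

The step from compound 2 to compound 3 removes the ring and the free carboxylic acid together, so the compounds shown cannot assign the loss to either change alone. A 2-(ethoxycarbonyl)pyrrolidin-1-yl group, which keeps the ring with the ester, and a (carboxymethyl)(methyl)amino group, which keeps the open chain with the acid, would separate the two.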